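The compounds below may be only part of what the source reports. "The series", "measured", "known", "first", "only" and "open" are said of these compounds alone.

Compound 1 `CCCCCCCc1ccc(NS(=O)(=O)c2ccc(N3CCNC3=O)cc2)cc1`: in a functional assay on HT-29 cells (Homo sapiens) for antiproliferative activity, read by sulforhodamine B assay, with a stated time of 48 h (on this read-out higher numbers stand for weaker inhibition and lower numbers for stronger inhibition), compound 1 gives > 1000 nM, which is a limit of the assay and not a number.
Compound 2 `O=C1NCCN1c1ccc(S(=O)(=O)Nc2ccccc2)cc1`: in this assay compound 2 gives 280 nM.
Compound 3 `CCc1cccc(NS(=O)(=O)c2ccc(N3CCNC3=O)cc2)c1`: in this assay compound 3 gives 110 nM.

Compound 3 holds the lowest of the two numbers measured; compound 2 is the nearest to it, as seen in a 2.5-fold lower number from compound 2 to compound 3 (0.41 log units; beyond the scatter), and the third value, that of compound 1, is only a limit (the limit of > 1000 nM in this assay, at which 1 of the 3 values shown sits).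

Compound 4 `COc1ccc(NS(=O)(=O)c2ccc(N3CCNC3=O)cc2)cc1` differs from compound 3 in a single place: 4-methoxyphenyl in place of 3-ethylphenyl on a sulfonamide nitrogen. For the measured compounds named here, two measured steps concern substituents on this same phenyl ring. Removing a heptyl gave an at least 3.5-fold lower number from compound 1 to compound 2 (0.55 log units; beyond the scatter), and adding an ethyl gave a 2.5-fold lower number from compound 2 to compound 3 (0.41 log units; beyond the scatter). Both steps were of modest size, and neither exceeded a modest change in either direction. The methoxy group of compound 4 is a different substituent on the ring from the ethyl of compound 3, so the expectation for compound 4 is a number somewhat higher than that of compound 3, with the step of a 1.8-fold higher number from compound 3 to compound 4 (0.26 log units; within the scatter) expected to be modest at most. Compound 4 is therefore estimated at 200 nM in this assay, in the range from 70 nM to 600 nM.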

Compound 4, half-maximal inhibitory concentration: 800 nM
The estimate for compound 4 lay 4.0-fold (0.60 log units) below the measured number, and the stated range ends below it.
By their numbers in this assay, from the lowest: compound 3; then compound 2; then compound 4. At a limit, above all of these: compound 1.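

The phenyl ring on the sulfonamide nitrogen does not respond to every added group in the same way in this assay: adding ethyl gave a 2.5-fold lower number from compound 2 to compound 3 (0.41 log units; beyond the scatter), whereas adding methoxy gave a 2.9-fold higher number from compound 2 to compound 4 (0.46 log units; beyond the scatter). Replacing 3-ethylphenyl with 4-methoxyphenyl gives a 7.3-fold higher number from compound 3 to compound 4 (0.86 log units; beyond the scatter), so two groups of equal heavy-atom count can still read very differently at this place. Compound 1 stands at a limit and not at a number: the limit of > 1000 nM in this assay, at which 1 of the 4 values shown sits. Methoxy in place of heptyl gives only a floor, an at least 1.2-fold lower number from compound 1 to compound 4 (0.09 log units; that floor lies within the scatter).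

This change alters both the group and its place on the ring, and the compounds shown do not separate those two contributions. From the compounds shown here alone, how an amine or a carboxylic acid on this ring would read also remains open.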